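Ring substituent variation on the shared core

The source may hold more compounds than are shown below. What is called first, only, known or untested is meant among the compounds shown, and "the series" means these compounds.

Measured in a functional assay on HeLa cells (Homo sapiens) for antiproliferative activity, read by sulforhodamine B assay, with a stated time of 48 h; a lower number here means a stronger inhibitor, a higher number a weaker inhibitor:
compound 1 `COC(=O)c1cc(NC2=NC(=O)/C(=C/c3ccc(C)cc3)S2)ccc1O` gives 85 nM;
compound 2 `COC(=O)c1cc(NC2=NC(=O)/C(=C/c3ccccc3O)S2)ccc1O` gives 1390 nM;
compound 3 `COC(=O)c1cc(NC2=NC(=O)/C(=C/c3ccc(Br)cc3)S2)ccc1O` gives 3480 nM.

Compound 3 gives the highest number of the three: a 2.5-fold higher number from compound 2 to compound 3 (0.40 log units; beyond the scatter) and a 41-fold higher number from compound 1 to compound 3 (1.61 log units; beyond the scatter). Compound 4 `COC(=O)c1cc(NC2=NC(=O)/C(=C/c3ccc(N(C)C)cc3)S2)ccc1O` differs from compound 3 by dimethylamino in place of bromo on an aromatic carbon. The step that bears on it most directly is the earlier change at an aromatic carbon, a 41-fold higher number from compound 1 to compound 3 (1.61 log units; beyond the scatter), which was large; a 16-fold higher number from compound 1 to compound 2 (1.21 log units; beyond the scatter) shows that another ring substituent change also moved the number a great deal. With three measured points the direction for a dimethylamino group is uncertain, but a return toward the lower number of compound 1 in this assay seems more likely than a further rise. The step is therefore expected as a 5.8-fold lower number from compound 3 to compound 4 (0.76 log units; beyond the scatter). Compound 4 is estimated at 600 nM, within 100 nM to 4000 nM.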

Compound 4, half-maximal inhibitory concentration: 180 nM
For compound 4 the middle estimate is 3.3-fold (0.52 log units) above the measured one, and the stated range covers the measured number.
By their numbers in this assay, from the lowest: compound 1; then compound 4; then compound 2; then compound 3.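

Replacing bromo with dimethylamino on the aromatic carbon para to a large group takes the number almost all the way back down (a 19-fold lower number from compound 3 to compound 4 (1.29 log units; beyond the scatter)), so this carbon accepts a substituent of three heavy atoms without the loss seen with bromo. Dimethylamino also stands clear of the 2-hydroxyphenyl compound (a 7.7-fold lower number from compound 2 to compound 4 (0.89 log units; beyond the scatter)) but does not quite match methyl (a 2.1-fold higher number from compound 1 to compound 4 (0.33 log units; beyond the scatter)). No evidence is available on what separates these groups.

Going by these compounds, a methoxy group, a primary amine or a carboxylic acid on this same carbon remains open.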